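Replacing a methylsulfonyloxy group with piperazine on a shared core

The source may hold more compounds than are shown below. What is called first, only, known or untested is meant among the compounds shown, and "the series" means these compounds.

Compound 1, `CS(=O)(=O)Oc1c(C(=O)NCc2ccc(F)cc2)nc(Br)c2cccnc12`: in a functional assay on HCT-116 cells (Homo sapiens) for cytotoxicity, read by MTT assay, with a stated time of 72 h (on this read-out higher numbers stand for weaker inhibition and lower numbers for stronger inhibition), compound 1 gives > 20000 nM, which is a limit of the assay and not a number.
Compound 2, `O=C(NCc1ccc(F)cc1)c1nc(Br)c2cccnc2c1NCc1ccc(F)cc1`: in this assay compound 2 gives > 20000 nM, again a limit.
Compound 3, `O=C(NCc1ccc(F)cc1)c1nc(Br)c2cccnc2c1NCCO`: in this assay compound 3 gives > 20000 nM, also a limit.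

Compound 1 therefore stands only at a limit, and the same holds for the other two, all three sitting at the same ceiling (the limit of > 20000 nM in this assay, at which 3 of the 3 values shown sit). Compound 4, `O=C(NCc1ccc(F)cc1)c1nc(Br)c2cccnc2c1N1CCNCC1`, has not yet been measured. It differs from compound 1 in one place: piperazin-1-yl in place of (methylsulfonyl)oxy on an aromatic carbon. The measured steps that bear on this change are the two that likewise exchange the (methylsulfonyl)oxy group on the same aromatic carbon, a step that the two limits leave unreadable from compound 1 to compound 2 and a step that the two limits leave unreadable from compound 1 to compound 3. Neither step has a readable size because the limit of > 20000 nM in this assay, at which 3 of the 3 values shown sit, sits at both ends of each. No direction or size of step in this assay beyond the scatter can be drawn from them, and the likeliest outcome is one more limit. Compound 4 is expected to give about 30000 nM, within 10000 nM to 100000 nM. The step this estimate implies, a step that the limit leaves unreadable from compound 1 to compound 4, is expected to stay unreadable.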

Compound 4, half-maximal inhibitory concentration: > 10000 nM
Compound 4 ended at the assay's limit (the forecaster's own chance of this, stated with the estimate: 80%); the middle value is on the limit's open side.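

Going by these compounds alone, compound 1, compound 2, compound 3 and compound 4 all stand at limits in this assay, not at numbers, and no step linking compound 4 to the other three can be read. From the compounds shown here alone, how strongly any of them inhibits, and whether exchanging this group changes that, stays open.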